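A few compounds are considered here, and "the series" means these few. Any claim that something is new, unique, unknown or untested is made for them only; others in the source may bear on it.

Measured in a functional assay on MCF7 cells (Homo sapiens) for cytotoxicity, read by MTT assay, with a stated time of 48 h (on this read-out lower numbers stand for stronger inhibition and higher numbers for weaker inhibition), so far:
Compound 1 (`Cc1ncc([N+](=O)[O-])n1CCSc1nnc(-c2ccccc2)o1`) gives 20500 nM
Compound 2 (`Cc1ncc([N+](=O)[O-])n1CCSc1nnc(-c2ccccc2Cl)o1`) gives 22500 nM
Compound 3 (`Cc1ncc([N+](=O)[O-])n1CCSc1nnc(-c2ccc(Cl)cc2)o1`) gives 18700 nM

Among the compounds with values here, compound 3 gives 18700 nM in this assay and sits level with the other two compounds, with no step to either beyond the scatter. Compound 4 (`Cc1ncc([N+](=O)[O-])n1CCSc1nnc(-c2cccnc2)o1`) keeps the shared core and carries pyridin-3-yl in place of 4-chlorophenyl on an aromatic carbon. Within the data shown here, three measured steps bear on this change. Chloro in place of hydrogen on an aromatic carbon gave two small steps (a 1.1-fold higher number from compound 1 to compound 2 (0.04 log units; within the scatter)) and (a 1.1-fold lower number from compound 1 to compound 3 (0.04 log units; within the scatter)), and 4-chlorophenyl in place of 2-chlorophenyl gave another (a 1.2-fold lower number from compound 2 to compound 3 (0.08 log units; within the scatter)). All three stay within the scatter. Among the measured compounds shown here, no measured compound carries pyridin-3-yl, and these steps cover the exchange only in part. On this evidence no step beyond the scatter is expected in this assay and no firm direction can be given. The estimated step (a 1.2-fold higher number from compound 3 to compound 4 (0.07 log units; within the scatter)) is expected to stay within the scatter. For compound 4 the expected value is 22000 nM with an estimated range (11000 nM to 45000 nM).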

Compound 4, half-maximal inhibitory concentration: 28700 nM
Beside the measured number, compound 4's estimate is 1.3-fold (0.12 log units) below it; the range from low to high includes it.
By their numbers in this assay, from the lowest: compounds 3, 1, 2 and 4 (each within the scatter of the next).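

In this assay, within the data shown here, compound 4 shows a ring nitrogen at this position for the first time in the comparison, on an aromatic carbon of a five-membered aromatic ring with 2 nitrogen and 1 oxygen, and the exchange goes from 0 hydrogen-bond acceptors in 4-chlorophenyl to 1 in pyridin-3-yl. Even with this change of ring, all three new steps stay within the scatter (a 1.5-fold higher number from compound 3 to compound 4 (0.19 log units; within the scatter)) (a 1.3-fold higher number from compound 2 to compound 4 (0.11 log units; within the scatter)) (a 1.4-fold higher number from compound 1 to compound 4 (0.15 log units; within the scatter)). The position therefore accepts a six-membered aromatic ring with 1 hetero atom as well as one of carbon only, without a step beyond the scatter, and the four compounds stand level in this assay. Nothing measured alongside these numbers speaks to what lies behind them.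

The compounds shown leave open whether pyridin-4-yl, or an aromatic ring bearing an amine or a carboxylic acid, would give a step beyond the scatter at this position. Going by these compounds, it also remains open whether replacing the aromatic ring with a longer alkyl chain, or changing the nitro group elsewhere on the shared core, would move the number further than any step seen here.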